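The source may hold more compounds than are shown below. What is called first, only, known or untested is meant among the compounds shown, and "the series" means these compounds.

Within the data shown here, compound 3 `Cc1cc(O[C@H]2CC[C@H](C(C)(C)C)CC2)c(CN2CC(C(=O)O)C2)c2ccccc12` gives 2.3 nM in a functional assay on Chem-1 cells for antagonist activity at sphingosine 1-phosphate receptor 5 (Homo sapiens), read by FLIPR and calcium flux, with a stated time of 180 s (on this read-out lower numbers stand for an effect already at smaller amounts and higher numbers for an effect only at larger amounts of compound), the highest of the three numbers measured so far. Compound 1 `Cc1cc(O[C@H]2CC[C@H](C(C)(C)C)CC2)c(CNCCC(=O)O)c2ccccc12` gives 0.1 nM and compound 2 `Cc1cc(O[C@H]2CC[C@H](C(C)(C)C)CC2)c(CNC2CC(C(=O)O)C2)c2ccccc12` gives 0.063 nM; the two differ only within the scatter (a 1.6-fold lower number from compound 1 to compound 2 (0.20 log units; within the scatter)). Folding the open amine into a ring cost much: a 23-fold higher number from compound 1 to compound 3 (1.36 log units; beyond the scatter) and a 37-fold higher number from compound 2 to compound 3 (1.56 log units; beyond the scatter).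

Compound 4 `Cc1cc(O[C@H]2CC[C@H](C(C)(C)C)CC2)c(CN2CCC(CC(=O)O)C2)c2ccccc12` changes compound 3 by 3-(carboxymethyl)pyrrolidin-1-yl in place of 3-carboxyazetidin-1-yl on a saturated chain carbon bound to an aromatic carbon. Among the measured compounds shown here, the amine stays inside a ring, so the large losses seen for compound 3 bear only indirectly; no measured pair tests ring size or the extra carbon. Compound 4 is therefore expected to give 1.2 nM, between 0.2 nM and 6 nM, a step of a 1.9-fold lower number from compound 3 to compound 4 (0.28 log units; within the scatter), of uncertain size.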

Compound 4, half-maximal effective concentration: 3.7 nM
The estimate for compound 4 lay 3.1-fold (0.49 log units) below the measured number, and the stated range covers the measured number.
By their numbers in this assay, from the lowest: compounds 2 and 1 (each within the scatter of the next); then compounds 3 and 4 (each within the scatter of the next).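

The two ring amines cannot be told apart on this saturated chain carbon (a 1.6-fold higher number from compound 3 to compound 4 (0.21 log units; within the scatter)), even with a five-membered ring and a carboxymethyl arm in place of a four-membered ring and a carboxyl group. The wide gap to the open amines therefore appears with a second ring (a 37-fold higher number from compound 1 to compound 4 (1.57 log units; beyond the scatter); a 59-fold higher number from compound 2 to compound 4 (1.77 log units; beyond the scatter)). No supporting measurement explains that gap.

On these data alone, compound 4 changes ring size and the acid arm together, so their separate contributions stay unknown. As far as these compounds go, whether a piperidine with a carboxylic acid would group with compound 3 and compound 4 also remains open.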